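Compound 3 to compound 4: swapping 4-methylphenyl for cyclohexyl

This account rests on a few compounds, and the source may have more. Where it says the series, first, only, none or still open, it means among the compounds named here.

Three compounds have been measured in an ADME assay on the whole organism (strain Sprague-Dawley) for pharmacokinetics, with Rattus norvegicus as the target, at a dose of 5 mg/kg by the oral route (on this read-out higher numbers stand for higher oral bioavailability and lower numbers for lower oral bioavailability), so far

Compound 1 `CC(C)c1ccc2c(Nc3cc(C(=O)N[C@@](C)(CO)c4ccccc4)ccc3Sc3ccc(N)cc3)ncnc2n1` gives 13.3%
Compound 2 `COC(=O)Nc1ccc(Sc2ccc(C(=O)N[C@@H](C)c3ccccc3)cc2Nc2ncnc3nc(C(C)C)ccc23)cc1` gives 0%
Compound 3 `Cc1ccc([C@H](C)NC(=O)c2ccc(Sc3ccc(N)cc3)c(Nc3ncnc4nc(C(C)C)ccc34)c2)cc1` gives 12.2%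

Compound 3 at 12.2% cannot be told apart from compound 1 at 13.3% within the scatter, while compound 2 at 0% lies lower than both, beyond the scatter.

Compound 4 `CC(C)c1ccc2c(Nc3cc(C(=O)N[C@@H](C)C4CCCCC4)ccc3Sc3ccc(N)cc3)ncnc2n1` differs from compound 3 in one place (cyclohexyl in place of 4-methylphenyl on a saturated chain carbon bound to an amide-type nitrogen and a saturated chain carbon), with cyclohexyl in place of 4-methylphenyl on a saturated chain carbon bound to an amide-type nitrogen and a saturated chain carbon. For the measured compounds named here, the one measured step on the same amide-type nitrogen is a number 1.1 percentage points lower from compound 1 to compound 3 (within the scatter) with 1-(4-methylphenyl)ethyl in place of 1-(hydroxymethyl)-1-phenylethyl. Going by the values given here, no measured step replaces an aromatic ring with a non-aromatic one. Among the compounds with values here, that single step is therefore the only guide, so no step beyond the scatter is expected in this assay and no direction can be favoured. The estimated step is a number 1.2 percentage points lower from compound 3 to compound 4 (within the scatter) and stays within the scatter. Compound 4 is expected at an estimated 11% with a range from 2% to 24% on this read-out.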

Compound 4, oral bioavailability: 5%
Beside the measured number, compound 4's estimate is 6 percentage points above it; low and high end bracket the measured number.
By their numbers in this assay, from the lowest: compounds 2, 4, 3 and 1 (each within the scatter of the next, the first and the last beyond it).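

In this assay, for the compounds shown here, the change gives a number 7.2 percentage points lower from compound 3 to compound 4 (within the scatter) and is the first measured case in which a non-aromatic ring, cyclohexyl, takes the place of an aromatic one, 4-methylphenyl, on this saturated chain carbon bound to an amide-type nitrogen and a saturated chain carbon. Set against the hydroxymethyl-bearing group of compound 1, 1-cyclohexylethyl on the amide-type nitrogen gives a number 8.3 percentage points lower from compound 1 to compound 4 (within the scatter) as a second step at this place, so all three compounds that differ only here, compound 1, compound 3 and compound 4, remain within the scatter of one another, and the aromatic character of the ring makes no difference that this read-out can resolve. Nothing available accounts for the value of compound 4 or links it to any property of the cyclohexyl ring.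

Going by these compounds, whether an open chain such as n-hexyl or a ring carrying an amine, such as piperidinyl, would also stay within the scatter of compound 3 remains open. So does the effect of a carboxylic acid on the cyclohexyl ring at this same place.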